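The source may hold more compounds than are shown below. What is called first, only, known or untested is meant among the compounds shown, and "the series" means these compounds.

- Compound 1 `COc1cc(OC)c(/C=C/S(=O)(=O)Nc2ccc(OC)c(N)c2)c(OC)c1`: 3 nM
- Compound 2 `COC(=O)C(Nc1cc(NS(=O)(=O)/C=C/c2c(OC)cc(OC)cc2OC)ccc1OC)c1ccc(F)cc1`: 2500 nM

Among the measured compounds shown here, in a functional assay on K562 cells (Homo sapiens) for cytotoxicity, read by trypan blue exclusion, with a stated time of 96 h (on this read-out lower numbers stand for stronger inhibition and higher numbers for weaker inhibition), compound 2 gives 2500 nM, the higher of the two numbers, and its only neighbour is compound 1 at 3 nM. Compound 3 `COC(=O)C(Nc1cc(NS(=O)(=O)/C=C/c2c(OC)cc(OC)cc2OC)ccc1OC)c1ccc(Cl)cc1` departs from compound 2 by chloro in place of fluoro on an aromatic carbon, para to a large group. For the measured compounds named here, one measured step bears on this, an 830-fold higher number from compound 1 to compound 2 (2.92 log units; beyond the scatter). It is large and beyond the scatter, but it records the whole (4-fluorophenyl)(methoxycarbonyl)methyl entering in place of hydrogen. Going by the values given here, no measured step exchanges fluoro for chloro, so its size cannot simply be carried over. Only a small change is expected at this far end of the substituent, with no clear direction and nothing beyond the scatter: the expected step is a 1.3-fold lower number from compound 2 to compound 3 (0.10 log units; within the scatter). Compound 3 is estimated at 2000 nM, with an expected range from 700 nM to 6000 nM.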

Compound 3, half-maximal inhibitory concentration: 2500 nM
Estimate against measurement, compound 3: 1.3-fold (0.10 log units) below; measured number inside the range.
By their numbers in this assay, from the lowest: compound 1; then compounds 2 and 3 (each within the scatter of the next).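

In this assay, the exchange of halogen gives no change at the digits printed from compound 2 to compound 3 (within the scatter), so on an aromatic carbon para to a large group, chloro and fluoro cannot be told apart. The large step on the nitrogen returns with the chlorinated substituent, an 830-fold higher number from compound 1 to compound 3 (2.92 log units; beyond the scatter), which shows that this step does not depend on fluoro being the halogen present. No measured evidence bears on either result.

Which part of the substituent carries the large step stays open, as the 4-halophenyl ring and the methoxycarbonyl enter together in both compound 2 and compound 3. Also open, as far as these compounds go, is whether a carboxylic acid in place of the methyl ester, or a bromo or methoxy group on the ring, would leave the number where it stands.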